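Methylating the Amide Nitrogen of a Weak Inhibitor

The compounds below may be only part of what the source reports. "The series", "measured", "known", "first", "only" and "open" are said of these compounds alone.

Compound 3 `CC(NC(=O)c1ccc[nH]1)c1ccccc1` was tested in an assay on mitochondria for inhibition of Amine oxidase [flavin-containing] B (Bos taurus), read by fluorescence (a lower number here means a stronger inhibitor, a higher number a weaker inhibitor), where compound 3 gives 61800 nM. Among the three measured compounds that is the second highest number: compound 1 `CN(Cc1ccccc1)C(=O)c1ccc[nH]1` gives 150000 nM, weaker beyond the scatter, while compound 2 `CN(CCCc1ccccc1)Cc1ccc[nH]1` gives 2000 nM, far stronger. Compound 4 `CC(c1ccccc1)N(C)C(=O)c1ccc[nH]1` is not yet measured; it differs from compound 3 by methyl in place of hydrogen on an amide-type nitrogen. Within the data shown here, no measured pair shows this change alone, so its size is open. Compound 1 also carries a methyl on its amide-type nitrogen and sits at the weak end, but its other group differs, so it is only a loose guide. A small step in this assay is expected, toward weaker or none beyond the scatter. Compound 4 is estimated at 80000 nM, between 25000 nM and 250000 nM. The expected step is a 1.3-fold higher number from compound 3 to compound 4 (0.11 log units; within the scatter).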

Compound 4, inhibition constant: 4500 nM
The estimate for compound 4 lay 18-fold (1.25 log units) above the measured number; the whole stated range lies above it.
By their numbers in this assay, from the lowest: compound 2; then compound 4; then compound 3; then compound 1.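

In this assay, methyl in place of hydrogen on the amide-type nitrogen gives a 14-fold lower number from compound 3 to compound 4 (1.14 log units; beyond the scatter), so one added carbon at this position can matter greatly. Methyl in place of hydrogen on the saturated chain carbon gives a 33-fold lower number from compound 1 to compound 4 (1.52 log units; beyond the scatter), so compound 4 needs both methyl groups to reach its number among these amides. Nothing measured here explains either step. Still open, from the compounds shown here alone, is whether methyl on the amide-type nitrogen gives a similar step without the chain methyl, and what an ethyl group or a longer chain would do on that nitrogen.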